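The source may hold more compounds than are shown below. What is called first, only, known or untested is meant among the compounds shown, and "the series" means these compounds.

Measured in an ADME assay on L6 cells (Rattus norvegicus) for cytotoxicity, read by resazurin assay, with a stated time of 72 h; on this read-out lower numbers stand for stronger inhibition and higher numbers for weaker inhibition:
- compound 1 `Cc1csc(C(=O)NCCCn2cnc([N+](=O)[O-])n2)c1`: 173000 nM
- compound 2 `O=C(NCCCCn1cnc([N+](=O)[O-])n1)c1ccsc1`: > 339000 nM (a limit of the assay, not a number)

Within the data shown here, compound 1 carries the only true number in this assay. Compound 3 `Cc1ccoc1C(=O)NCCCn1cnc([N+](=O)[O-])n1` keeps the rest of compound 1 and changes in one place, on a carbonyl carbon: 3-methylfuran-2-yl in place of 4-methylthiophen-2-yl on a carbonyl carbon. Among the measured compounds shown here, no step between measured compounds is available, so the expectation starts from compound 1 at 173000 nM and assumes no shift in either direction beyond the scatter. The estimated change is a 1.2-fold higher number from compound 1 to compound 3 (0.06 log units; within the scatter). Compound 3 is expected at 200000 nM, within an estimated range of 90000 nM to 400000 nM.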

Compound 3, half-maximal inhibitory concentration: > 358000 nM
Compound 3 was reported as a limit; the forecaster's own chance of this, stated with the estimate: 25%; middle value at least 1.7-fold (0.25 log units) from the limit.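

In this assay, the group on the carbonyl carbon proves able to move the read-out: 3-methylfuran-2-yl in place of 4-methylthiophen-2-yl gives an at least 2.0-fold higher number from compound 1 to compound 3 (0.31 log units; beyond the scatter). Among these compounds, this is the first readable step, and it shows weaker inhibition with the furan. Its size is only a minimum, since compound 3 has a limit and not a number: the limit of > 358000 nM in this assay, at which 1 of the 3 values shown sits.

The step does not separate the change of ring hetero atom from the change in the methyl group's placement. As far as these compounds go, how an amine or a carboxylic acid would read on this carbonyl carbon also remains open.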